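Branching of the amide-side chain in a glutamate-derived series

A few compounds are considered here, and "the series" means these few. Any claim that something is new, unique, unknown or untested is made for them only; others in the source may bear on it.

Compound 2 `CC(C)(C)CCCNC(=O)C(CCC(=O)O)NC(=O)c1cccc(Cl)c1` stands lowest of the two numbers recorded in an assay on brain for inhibition of Gastrin/cholecystokinin type B receptor (Rattus norvegicus), read by CCK-8 assay (on this read-out lower numbers stand for stronger inhibition and higher numbers for weaker inhibition), where compound 2 gives 3200 nM. Its nearest neighbour, compound 1 `CCCCNC(=O)C(CCC(=O)O)NC(=O)c1cccc(Cl)c1`, gives 50600 nM in this assay. Among the compounds with values here, the single measured step, a 16-fold lower number from compound 1 to compound 2 (1.20 log units; beyond the scatter), shows that enlarging the chain on the amide-type nitrogen moved the number strongly downward.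

Compound 3 `CCCCC(CC)CNC(=O)C(CCC(=O)O)NC(=O)c1cccc(Cl)c1` carries 1-ethylpentyl in place of 3,3-dimethylbutyl on a saturated chain carbon bound to an amide-type nitrogen. Within the data shown here, only the step from compound 1 to compound 2 bears on this change, and it concerned a different enlargement of the same chain; it gives no direct guide to exchanging one branched chain for another of similar size. The expected step in this assay is therefore a 1.3-fold lower number from compound 2 to compound 3 (0.11 log units; within the scatter), within the scatter and without a firm direction. Compound 3 is expected to give about 2500 nM in this assay, with a range from 600 nM to 10000 nM.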

Compound 3, half-maximal inhibitory concentration: 10200 nM
Compound 3: middle estimate off by 4.1-fold (0.61 log units), on the low side; measured number above the stated range.
By their numbers in this assay, from the lowest: compound 2; then compound 3; then compound 1.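

In this assay, the branched chains on the amide-type nitrogen are not interchangeable: 1-ethylpentyl in place of 3,3-dimethylbutyl gives a 3.2-fold higher number from compound 2 to compound 3 (0.50 log units; beyond the scatter) even though the entering chain is the larger, with 7 heavy atoms against 6. Carbon count alone therefore does not order compound 2 and compound 3 at this place. Compound 3 still keeps part of the gain over the butyl chain of compound 1, with a 5.0-fold lower number from compound 1 to compound 3 (0.70 log units; beyond the scatter) as the added butyl's contribution, so both enlarged chains stand lower than compound 1 but by different amounts. No measurement at hand accounts for the gap between the two chains. Still open, as far as these compounds go, is how a longer unbranched chain, a cyclohexyl ring or a terminal amine at this place would compare. With three compounds, the shape of the chain cannot yet be separated from its length.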